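The compounds below may be only part of what the source reports. "The series", "measured", "known", "first", "only" and "open" are said of these compounds alone.

Compound 1 `COc1cccc(S(=O)(=O)/C=C/c2ccccn2)c1` and compound 2 `COc1cccc(S(=O)(=O)/C=C/c2cccc(Cl)n2)c1` share one core, while compound 3 `COc1ccccc1S(=O)(=O)/C=C/c1cccnc1Cl` and compound 4 `COc1ccccc1S(=O)(=O)/C=C/c1ccc(Cl)nc1Cl` share another; the difference between the two cores is not broken down here. In an ADME assay on BV-2 cells (Mus musculus) for cytotoxicity, with a stated time of 24 h, tested at 50 uM (on this read-out higher numbers stand for a weaker effect at the one concentration tested and lower numbers for a stronger effect), compound 1 gives 98.9%, compound 2 gives 89.3%, and compound 3 gives 87.5%. From compound 1 to compound 2 the change is chloro in place of hydrogen on an aromatic carbon, and it made a step of a number 9.6 percentage points lower from compound 1 to compound 2 (within the scatter). From compound 3 to compound 4 the change is chloro in place of hydrogen on an aromatic carbon, the same kind of change, though here the place is next to the ring nitrogen, meta to a chloro group and para to a large group rather than meta to a large group. Because the earlier step was a number 9.6 percentage points lower from compound 1 to compound 2 (within the scatter), compound 4 is expected to move by about a number 4.5 percentage points lower from compound 3 to compound 4 (within the scatter). Compound 4 is therefore estimated at 83%, with a likely range from 70% to 95%.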

Compound 4, a percentage reported as activity, at one concentration (the size of the read-out at that concentration, not a potency): 99.8%
The estimate for compound 4 lay 16.8 percentage points below the measured number, and the stated range ends below it.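

Putting chloro in place of hydrogen on an aromatic carbon gave a number 12.3 percentage points higher from compound 3 to compound 4 (beyond the scatter), so the step seen on the core of compound 1 did not carry over to the core of compound 3 in this assay. The two steps clearly differ: the same change on two cores in this assay, a number 9.6 percentage points lower (within the scatter) from compound 1 to compound 2 and a number 12.3 percentage points higher (beyond the scatter) from compound 3 to compound 4, 21.9 percentage points apart, beyond the scatter of two such steps. This shows that, in this series, the step on one core is a poor guide to the step on the other, but with one pair per core it does not show why, since the chloro also enters at a different place in each pair.

From the compounds shown here alone, it remains open whether chloro would give matching steps at the same place on both cores. Also open, going by these compounds, is how another group there, such as an amine or a carboxylic acid, would behave.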